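Benzyl to Methoxyphenyl on a Quinoline Thiosemicarbazone

The compounds below may be only part of what the source reports. "The series", "measured", "known", "first", "only" and "open" are said of these compounds alone.

Two thiosemicarbazones have been examined in a functional assay on HT-29 cells (Homo sapiens) for antiproliferative activity, read by sulforhodamine B assay, with a stated time of 72 h; a lower number here means a stronger inhibitor, a higher number a weaker inhibitor. Compound 1 `CN(C)C(=S)N/N=C/c1ccc2cccnc2n1` gives 410 nM in this assay. Compound 2 `S=C(NCc1ccccc1)N/N=C/c1ccc2ccccc2n1` gives 75700 nM in this assay, the higher of the two numbers and so the weaker result; compound 1 sits far from it, well beyond the usual scatter. Within the data shown here, no single-change step connects these two compounds, so only their two values can be set side by side.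

Compound 3 `COc1cccc(NC(=S)N/N=C/c2ccc3ccccc3n2)c1` differs from compound 2 in one place: 3-methoxyphenyl in place of benzyl on an amide-type nitrogen. Among the measured compounds shown here, with no measured step of this kind available, the expectation rests on the value of compound 2 alone. The step of a 2.5-fold lower number from compound 2 to compound 3 (0.40 log units; beyond the scatter) is expected to be a moderate move toward a lower number, just beyond the scatter rather than a large shift. For compound 3 the estimate in this assay is 30000 nM, with a range from 8000 nM to 100000 nM.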

Compound 3, half-maximal inhibitory concentration: 82400 nM
The estimate for compound 3 lay 2.7-fold (0.44 log units) below the measured number; the measured number falls inside the stated range.
By their numbers in this assay, from the lowest: compound 1; then compounds 2 and 3 (each within the scatter of the next).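

At the amide-type nitrogen whose other neighbour is the thiocarbonyl carbon, the exchange of benzyl for 3-methoxyphenyl gives no change that can be told from scatter in this assay, with a 1.1-fold higher number from compound 2 to compound 3 (0.04 log units; within the scatter) as the step. The entering group brings one more heavy atom, an oxygen, and one hydrogen-bond acceptor, yet this swap leaves the read-out where it was, so this first step at the position shows no sensitivity to it. Nothing available accounts for this outcome.

The compounds shown leave open whether a carboxylic acid or an amine on the aromatic ring, or a longer chain in place of benzyl, would move the number at this nitrogen. They also leave open whether the same exchange would behave alike on the core of compound 1.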